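Acid for amide on the pyridyl acrylamide series

The compounds below may be only part of what the source reports. "The series", "measured", "known", "first", "only" and "open" are said of these compounds alone.

Measured compounds:
- compound 1 `CNC(=O)/C=C/c1ccncc1-c1ccc2c(cnn2C)c1` gives > 10000 nM in a functional assay on A549 cells (Homo sapiens) for inhibition, read by sulforhodamine B assay, with a stated time of 72 h; on this read-out higher numbers stand for weaker inhibition of growth and lower numbers for stronger inhibition of growth; this is a limit of the assay.
- compound 2 `CNC(=O)/C=C/c1ccncc1-c1ccc2ccccc2c1` gives 6620 nM in this assay.
- compound 3 `NNC(=O)CCc1ccncc1-c1ccc2ccccc2c1` gives > 10000 nM in this assay; this is a limit of the assay.

Compound 1 stands at the limit of this assay, the point where the limit of > 10000 nM in this assay, at which 2 of the 3 values shown sit, sit, so no number is known for it, only that growth inhibition was weaker than the assay resolves. Among the compounds with values here, compound 2 is the only compound with a measured number. Within the data shown here, the one step measured, an at least 1.5-fold higher number from compound 2 to compound 3 (0.17 log units; that floor lies within the scatter), exchanges the amide and saturates the chain at once and ends at the limit; it does not contain the change studied here and bears on it only loosely.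

Compound 4 `Cn1ncc2cc(-c3cnccc3/C=C/C(=O)O)ccc21` differs from compound 1 by hydroxy in place of methylamino on a carbonyl carbon. Among the measured compounds shown here, no measured step covers this exchange. For the measured compounds named here, since compound 1 already sits at the limit and the only measured change to the amide did not improve matters, the expectation for compound 4 is a step that the limit leaves unreadable from compound 1 to compound 4, within the scatter, most likely again a limit. Compound 4 is estimated at 15000 nM in this assay, with a range from 5000 nM to 40000 nM.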

Compound 4, concentration for 50% growth inhibition: > 10000 nM
Compound 4 was reported as a limit; the forecaster's own chance of this, stated with the estimate: 75%; the middle value is on the limit's open side.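

Compound 1 and compound 4 are both reported only as limits in this assay, so no step can be read between them: the limit of > 10000 nM in this assay, at which 3 of the 4 values shown sit.

From the compounds shown here alone, whether hydroxy in place of methylamino on a carbonyl carbon changes growth inhibition at all stays open, on the core of compound 1 and on any compound with a measured number.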